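A few compounds are considered here, and "the series" means these few. Any claim that something is new, unique, unknown or untested is made for them only; others in the source may bear on it.

Measured compounds:

compound 1, `Nc1nc(Cl)c2ncn(Cc3ccc(CCl)cc3)c2n1` — 2570 nM
compound 2, `ClCc1cccc(Cn2cnc3c(Cl)nc(Cl)nc32)c1` — 1730 nM
compound 3, `ClCc1ccc(Cn2cnc3c(Cl)nc(Cl)nc32)cc1` — 17400 nM

In a functional assay on EKVX cells (Homo sapiens) for cytotoxicity, read by sulforhodamine B assay, with a stated time of 48 h (on this read-out higher numbers stand for weaker inhibition of growth and lower numbers for stronger inhibition of growth), compound 3 gives 17400 nM, and compound 1 gives 2570 nM. The change from compound 3 to compound 1 is amino in place of chloro on an aromatic carbon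
This gave a 6.8-fold lower number from compound 3 to compound 1 (0.83 log units; beyond the scatter). Compound 2 gives 1730 nM in this assay; its difference from compound 3 is not broken down here. Compound 2 and compound 1 lie within the scatter of each other.

Compound 4, `Nc1nc(Cl)c2ncn(Cc3cccc(CCl)c3)c2n1`, is not yet measured. Its change from compound 2 is amino in place of chloro on an aromatic carbon
The place lines of both changes agree word for word, so this is the same change already seen from compound 3 to compound 1. Compound 4 is therefore expected to show a 4.3-fold lower number from compound 2 to compound 4 (0.64 log units; beyond the scatter) in this assay, resting on the step from compound 3 to compound 1, a 6.8-fold lower number from compound 3 to compound 1 (0.83 log units; beyond the scatter), with some allowance for a different starting point. Compound 4 is estimated at 400 nM, between 120 nM and 1500 nM.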

Compound 4, concentration for 50% growth inhibition: 21400 nM
Compound 4: middle estimate off by 54-fold (1.73 log units), on the low side; the whole stated range lies below it.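

In this assay, amino in place of chloro on an aromatic carbon gave a 12-fold higher number from compound 2 to compound 4 (1.09 log units; beyond the scatter), which runs opposite to the same change on the other core: the same change on two cores in this assay, a 6.8-fold lower number (0.83 log units; beyond the scatter) from compound 3 to compound 1 and a 12-fold higher number (1.09 log units; beyond the scatter) from compound 2 to compound 4, 84-fold (1.92 log units) apart, beyond the scatter of two such steps

In this series, the change therefore cannot be carried from one core to another as a fixed step, not even in its direction. Two pairs do not show what separates the cores, nor which direction would be more usual on a further core.

The compounds shown leave open how a methylamino or methoxy group in place of the chloro would behave on either core. They also leave open whether the two cores would still part if a hydroxymethyl group replaced the chloromethyl group.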